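Quinazoline thioacetamides on prostate cancer cells

The source may report more compounds than this note shows. Statements on the series, on what has been measured and on what is new or still open speak of the compounds shown alone.

Compound 1 `O=C(CSc1nc(Nc2ccccc2)c2ccccc2n1)Nc1ccc(C(F)(F)F)cc1`: 10400 nM
Compound 2 `C=CC(=O)Nc1cccc(NC(=O)CSc2nc(Nc3cccc(Br)c3)c3ccccc3n2)c1`: 15000 nM

In a functional assay on PC-3 cells (Homo sapiens) for inhibition, read by MTT assay, with a stated time of 72 h (a lower number here means a stronger inhibitor, a higher number a weaker inhibitor), compound 1 gives 10400 nM and compound 2 gives 15000 nM. Compound 2 carries the higher of the two numbers, but the gap to compound 1 lies within the scatter, so the two cannot be told apart. Compound 3 `C=CC(=O)Nc1cccc(NC(=O)CSc2nc(Nc3ccc(Cl)cc3Cl)c3ccccc3n2)c1` has not yet been measured. It differs from compound 2 in one place: 2,4-dichlorophenyl in place of 3-bromophenyl on a nitrogen on an aromatic ring. Going by the values given here, no measured pair shows a step of this kind, so the expected change in this assay is none beyond the scatter, in either direction. For compound 3 the estimated value is 14000 nM with a range from 5000 nM to 40000 nM, a step of a 1.1-fold lower number from compound 2 to compound 3 (0.03 log units; within the scatter).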

Compound 3, half-maximal inhibitory concentration: 25700 nM
Compound 3: middle estimate off by 1.8-fold (0.26 log units), on the low side, and the stated range covers the measured number.
By their numbers in this assay, from the lowest: compounds 1, 2 and 3 (each within the scatter of the next, the first and the last beyond it).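

In this assay, 2,4-dichlorophenyl in place of 3-bromophenyl on a nitrogen on an aromatic ring gives a 1.7-fold higher number from compound 2 to compound 3 (0.23 log units; within the scatter), the first step read at this position. The two halogen-bearing phenyl groups therefore cannot be told apart here, whether by the number or kind of halogen. Nothing at hand bears on the reason for this result.

The compounds shown leave open whether a benzyl group or a pyridine ring at this position would give a step beyond the scatter.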